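Tert-butyl for amino on compound 2: cytotoxicity outlook

This account rests on a few compounds, and the source may have more. Where it says the series, first, only, none or still open, it means among the compounds named here.

Compound 1 `CC(/C=N/Nc1ccc([N+](=O)[O-])cc1)=N\NC(=O)c1ccccc1Cl` gives only a limit in an ADME assay on J774 cells (Mus musculus, strain BALB/c) for cytotoxicity, read by resazurin assay, with a stated time of 72 h (a higher number here means that more compound is tolerated, a lower number that less compound is tolerated), > 100000 nM. Compound 2 `CC(/C=N/Nc1ccc([N+](=O)[O-])cc1)=N\NC(=O)c1ccc(N)cc1` gives 75000 nM in this assay, and the change from compound 1 is an at least 1.3-fold lower number from compound 1 to compound 2 (0.12 log units; that floor lies within the scatter). Among the measured compounds shown here, compound 2 thus holds the only number in this assay; the other value is a limit (the limit of > 100000 nM in this assay, at which 1 of the 2 values shown sits). Compound 3 `CC(/C=N/Nc1ccc([N+](=O)[O-])cc1)=N\NC(=O)c1ccc(C(C)(C)C)cc1` differs from compound 2 by tert-butyl in place of amino on an aromatic carbon. For the measured compounds named here, the single measured step concerns the same aromatic ring and stays within the scatter, so for compound 3 an expected step of a 1.1-fold higher number from compound 2 to compound 3 (0.03 log units; within the scatter) in this assay, not beyond the scatter, is estimated. Compound 3 is expected at 80000 nM, range 30000 nM to 200000 nM.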

Compound 3, half-maximal cytotoxic concentration: > 100000 nM
Compound 3 gave a limit, no number; the forecaster's own chance of this, stated with the estimate: 40%; middle value at least 1.2-fold (0.09 log units) from the limit.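

On these data alone, the step reads an at least 1.3-fold higher number from compound 2 to compound 3 (0.12 log units; that floor lies within the scatter) in this assay, and it is open-ended, so the data do not separate compound 3 from compound 2. What is new is that this aromatic carbon accepts tert-butyl, with no hydrogen-bond donors or acceptors, and the reading of compound 3 is still only a limit. Limit readings now dominate the series: the limit of > 100000 nM in this assay, at which 2 of the 3 values shown sit.

As far as these compounds go, whether any group at this position moves the number beyond the scatter remains open. A carboxylic acid or a longer alkyl chain on the same aromatic carbon could test this.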